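Swapping the amide substituent for phenylsulfonyl in compound 4

The source may hold more compounds than are shown below. What is called first, only, known or untested is meant among the compounds shown, and "the series" means these compounds.

Compound 1 `Cc1cc(C)cc(S(=O)(=O)c2c(C(=O)N[C@@H]3CCNC3)[nH]c3ccc(Cl)cc23)c1`: 37300 nM
Compound 2 `Cc1cc(C)cc(S(=O)(=O)c2c(C(=O)NC3CN(Cc4cccnc4)C3)[nH]c3ccc(Cl)cc23)c1`: 36000 nM
Compound 3 `Cc1cc(C)cc(S(=O)(=O)c2c(C(=O)NC3CN(Cc4n[nH]c(=O)n4C)C3)[nH]c3ccc(Cl)cc23)c1`: 25200 nM

In an ADME assay on MT4 cells (Homo sapiens) for cytotoxicity, read by MTT assay, with a stated time of 5 days (a higher number here means that more compound is tolerated, a lower number that less compound is tolerated), compound 3 gives 25200 nM, a value within the scatter of those of both other compounds. The three measured compounds therefore form a single group on these numbers, and none of them can be ranked against another.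

The next compound is compound 4 `Cc1cc(C)cc(S(=O)(=O)c2c(C(=O)NS(=O)(=O)c3ccccc3)[nH]c3ccc(Cl)cc23)c1`. It keeps the shared core but differs from compound 3 on an amide-type nitrogen whose other neighbours are: carbonyl carbon. There, (a group of 9 heavy atoms (6 carbon, 2 oxygen, 1 sulfur; one six-membered aromatic ring of carbon only) in place of a group of 12 heavy atoms (7 carbon, 4 nitrogen, 1 oxygen; one four-membered non-aromatic ring with 1 hetero atom, one five-membered aromatic ring with 3 hetero atoms), on an amide-type nitrogen), and phenylsulfonyl is the group that enters.

Within the data shown here, three measured steps bear on this change. Two of them replace the group at this same nitrogen, giving a 1.0-fold lower number from compound 1 to compound 2 (0.02 log units; within the scatter) and a 1.5-fold lower number from compound 1 to compound 3 (0.17 log units; within the scatter). The third alters only the far end of the substituent and gives a 1.4-fold lower number from compound 2 to compound 3 (0.15 log units; within the scatter). All three lie within the scatter. Among the measured compounds shown here, none of the measured compounds carries phenylsulfonyl, however, so these steps offer only limited guidance and the range must stay wide.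

No step beyond the scatter is therefore expected, and no direction can be given. The expected step is a 1.2-fold higher number from compound 3 to compound 4 (0.08 log units; within the scatter). Compound 4 is estimated at 30000 nM, with an expected range from 11000 nM to 80000 nM.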

Compound 4, half-maximal cytotoxic concentration: 167000 nM
The estimate for compound 4 lay 5.6-fold (0.75 log units) below the measured number, and the stated range ends below it.
By their numbers in this assay, from the lowest: compounds 3, 2 and 1 (each within the scatter of the next); then compound 4.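

At this amide-type nitrogen, the pyrrolidin-3-yl and azetidine-bearing groups of compounds 1, 2 and 3 had all stayed within the scatter of one another in this assay, so the position had seemed indifferent to what it carried. Phenylsulfonyl is the first group there to give steps beyond the scatter: a 6.6-fold higher number from compound 3 to compound 4 (0.82 log units; beyond the scatter), a 4.6-fold higher number from compound 2 to compound 4 (0.67 log units; beyond the scatter) and a 4.5-fold higher number from compound 1 to compound 4 (0.65 log units; beyond the scatter). All three steps run the same way and are of similar size, towards more compound tolerated, so the position can affect this number, and compound 4 stands alone above a group of three that cannot be ranked against each other.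

The compounds shown do not separate the sulfonyl part of phenylsulfonyl from its phenyl ring, and a methylsulfonyl or a benzoyl group on this same nitrogen would speak to which part goes with the higher number. Nothing measured here accounts for the step.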